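The compounds below may be only part of what the source reports. "The series", "measured", "known", "first", "only" and "open" are said of these compounds alone.

In an assay on cells for inhibition of S-adenosylmethionine decarboxylase proenzyme (Homo sapiens), read by mass spectrometry, at pH 7.2 (on this read-out lower numbers stand for stronger inhibition and higher numbers for weaker inhibition), three compounds have been tested so far, and none of them gave a number. Compound 1 `CNc1nc(C)cc(Nc2cc(Cl)cc(Cl)c2)n1` reached only the limit of the measurement, > 63000 nM. Compound 2 `Cc1cc(N(C)c2cc(Cl)cc(Cl)c2)nc(N)n1` likewise stopped at a limit, > 180000 nM. Compound 3 `Cc1cc(Nc2cc(Br)cc(S(F)(F)(F)(F)F)c2)nc(N)n1` also gave only a limit in this assay, > 180000 nM. Two of the three readings sit at the same limit of > 180000 nM in this assay, at which 2 of the 3 values shown sit, and the third at another one (the limit of > 63000 nM in this assay, at which 1 of the 3 values shown sits), so compound 3 cannot be ranked against compound 1 or compound 2, and nothing more than a limit is known for it. Compound 4 `Cc1cc(Nc2cccc(Br)c2)nc(N)n1` is the next to be measured in this assay. It differs from compound 3 in a single place: a hydrogen atom in place of a group of 6 heavy atoms (5 fluorine, 1 sulfur; no ring), on an aromatic carbon. For the measured compounds named here, every value so far is a limit. Going by the values given here, there is no step between measured compounds against which this change could be calibrated. Compound 4 is therefore expected to stay at or beyond the limit as well. The step of a number no higher from compound 3 to compound 4 (the limit leaves the size open) is expected to lie within the scatter. The estimate for compound 4 is 180000 nM, with a range from 50000 nM to 600000 nM.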

Compound 4, half-maximal inhibitory concentration: > 180000 nM
Compound 4: no number, only a limit (the forecaster's own chance of this, stated with the estimate: 80%); the middle value sits exactly at the limit.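

Compound 3 and compound 4 both gave only a limit, so no step can be read between them, and swapping the group of 6 heavy atoms for a hydrogen atom has no readable size. The compounds shown leave open which structure, if any, would give an actual number rather than a limit.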